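Chalcone series: chloro for benzyloxy on the styryl ring

A few compounds are considered here, and "the series" means these few. Any claim that something is new, unique, unknown or untested is made for them only; others in the source may bear on it.

Measured so far:
compound 1 `O=C(/C=C/c1ccc(OCc2ccccc2)cc1)c1ccccc1` — 49.5%
compound 2 `Cc1ccc(COc2ccc(C(=O)/C=C/c3ccc(Cl)cc3)cc2)cc1` — 16.9%

Compound 1 holds the higher of the two numbers in a functional assay on HCT-116 cells (Homo sapiens) for antiproliferative activity, read by sulforhodamine B assay, with a stated time of 3 days, tested at 50 uM; a higher number here means a stronger effect of the compound at the concentration tested, a lower number a weaker effect; compound 2 sits lower by a gap beyond the scatter. Compound 3 `O=C(/C=C/c1ccc(Cl)cc1)c1ccccc1` has not been tested. It differs from compound 1 as follows: chloro in place of benzyloxy on an aromatic carbon. Going by the values given here, no measured pair shows this change alone, so its size is unknown. The step of a number 24.5 percentage points lower from compound 1 to compound 3 (beyond the scatter) is expected to go downward, because compound 2, which also carries chloro in place of the benzyloxy-bearing position, gives 16.9%. Compound 3 is estimated at 25%, within 5% to 48%.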

Compound 3, a percentage reported as inhibition, at one concentration (the size of the read-out at that concentration, not a potency): 100%
For compound 3 the middle estimate is 75 percentage points below the measured one, outside the stated range (above it).
By their numbers in this assay, from the lowest: compound 2; then compound 1; then compound 3.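

In this assay, chloro in place of benzyloxy gives a number 50.5 percentage points higher from compound 1 to compound 3 (beyond the scatter), so the benzyloxy group and its ring are not required at this position for the effect at the concentration tested. Going by these compounds alone, this is the first reading of this change alone, as compound 2 differs from compound 3 in more than one place. Nothing available bears on the reason for this step.

Going by these compounds, whether a methoxy group or an amine at this position would keep the effect remains open. A single-concentration read-out also leaves the potency of compound 3 open.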